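Moving a Methyl Group on the Outer Ring

The source may hold more compounds than are shown below. What is called first, only, known or untested is meant among the compounds shown, and "the series" means these compounds.

In a functional assay for agonist activity at G protein-coupled receptor 88 (Homo sapiens), read by HTRF and cAMP accumulation (a higher number here means that more compound is needed for the effect, a lower number that less compound is needed), compound 1 `CC(C)C[C@H](N)CN(C(=O)[C@@H]1C[C@H]1c1ccccc1)c1ccc(-c2ccccc2)cc1` gives 880 nM. Compound 2 `CC(C)C[C@H](N)CN(C(=O)[C@@H]1C[C@H]1c1ccccc1)c1ccc(C2=CCCCCC2)cc1` gives 2100 nM, and compound 3 `Cc1ccc(-c2ccc(N(C[C@@H](N)CC(C)C)C(=O)[C@@H]3C[C@H]3c3ccccc3)cc2)cc1` gives 360 nM. Compound 3 therefore has the lowest number of the three, shown by a 2.4-fold lower number from compound 1 to compound 3 (0.39 log units; beyond the scatter) and a 5.8-fold lower number from compound 2 to compound 3 (0.77 log units; beyond the scatter). Compound 4 `Cc1cccc(-c2ccc(N(C[C@@H](N)CC(C)C)C(=O)[C@@H]3C[C@H]3c3ccccc3)cc2)c1` differs from compound 3 in one place: 3-methylphenyl in place of 4-methylphenyl on an aromatic carbon. Going by the values given here, no measured step moves a methyl from one spot to another; the nearest guide is a 2.4-fold lower number from compound 1 to compound 3 (0.39 log units; beyond the scatter), which came from adding that methyl to compound 1. Compound 4 keeps the methyl, so only a modest step is expected, probably toward a somewhat higher number, as a 1.5-fold higher number from compound 3 to compound 4 (0.18 log units; within the scatter). The estimate for compound 4 is 550 nM, with a range from 220 nM to 1400 nM.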

Compound 4, half-maximal effective concentration: 1200 nM
Compound 4: middle estimate off by 2.2-fold (0.34 log units), on the low side, within the range that was stated.
By their numbers in this assay, from the lowest: compound 3; then compounds 1, 4 and 2 (each within the scatter of the next, the first and the last beyond it).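

The position of the methyl on the outer ring matters: 3-methylphenyl in place of 4-methylphenyl, with the same atoms, gives a 3.3-fold higher number from compound 3 to compound 4 (0.52 log units; beyond the scatter). The lower number of compound 3 therefore belongs to the 4-methylphenyl group, not to any methyl on that ring, since the step from the unsubstituted phenyl reads a 1.4-fold higher number from compound 1 to compound 4 (0.13 log units; within the scatter) and the step from cyclohept-1-en-1-yl reads a 1.8-fold lower number from compound 2 to compound 4 (0.24 log units; within the scatter). Nothing available explains why moving the methyl has this effect.

Still open, from the compounds shown here alone, is whether an ethyl, a methoxy or a chlorine in place of the methyl of compound 3 would give a lower number.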